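The source may report more compounds than this note shows. Statements on the series, on what has been measured and on what is new or still open speak of the compounds shown alone.

Compound 2 `Cc1cc(-c2c(F)cc3c(=O)c(Cc4cc(O)ccc4O)cn(C4CC4)c3c2F)cc(C)n1` gives 360 nM in a functional assay on P388 cells (Mus musculus) for cytotoxicity (on this read-out higher numbers stand for weaker inhibition and lower numbers for stronger inhibition), the lowest of the three numbers obtained. Compound 3 `Cc1cc(-c2c(F)cc3c(=O)c(Cc4c(O)cc(O)cc4O)cn(C4CC4)c3c2F)cc(C)n1` stands nearest, giving 470 nM, and the gap a 1.3-fold higher number from compound 2 to compound 3 (0.12 log units; within the scatter) lies within the scatter. Compound 1 `Cc1cc(-c2c(F)cc3c(=O)ccn(C4CC4)c3c2F)cc(C)n1`, which carries hydrogen where the other two carry a benzyl group, gives 15000 nM, and the steps of a 42-fold lower number from compound 1 to compound 2 (1.62 log units; beyond the scatter) and a 32-fold lower number from compound 1 to compound 3 (1.50 log units; beyond the scatter) are both large. Compound 4 `Cc1cc(-c2c(F)cc3c(=O)c(Cc4c[nH]cn4)cn(C4CC4)c3c2F)cc(C)n1` has not been measured; it differs from compound 2 in that (1H-imidazol-4-yl in place of 2,5-dihydroxyphenyl on a saturated chain carbon bound to an aromatic carbon). For the measured compounds named here, no measured step exchanges this aryl for a heteroaryl, so the measured steps bear on it only indirectly: they show that placing a benzyl-type group on this carbon lowers the number strongly, while the exchange of one hydroxyl pattern for another between compound 2 and compound 3 stays within the scatter. Compound 4 is therefore expected to show only a modest rise, a 1.9-fold higher number from compound 2 to compound 4 (0.29 log units; within the scatter). The estimated value for compound 4 is 700 nM, with a range from 200 nM to 3000 nM.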

Compound 4, half-maximal inhibitory concentration: 390 nM
Compound 4: middle estimate off by 1.8-fold (0.25 log units), on the high side; the range from low to high includes it.
By their numbers in this assay, from the lowest: compounds 2, 4 and 3 (each within the scatter of the next); then compound 1.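

On the saturated chain carbon bound to an aromatic carbon, the hydroxylated phenyl rings turn out not to be needed in this assay: 1H-imidazol-4-yl, a five-membered aromatic ring with 2 hetero atoms and no oxygen, leaves the read-out within the scatter, with a 1.1-fold higher number from compound 2 to compound 4 (0.03 log units; within the scatter) and a 1.2-fold lower number from compound 3 to compound 4 (0.08 log units; within the scatter). The large step from hydrogen therefore does not belong to the hydroxylated benzyl groups alone, as a 38-fold lower number from compound 1 to compound 4 (1.59 log units; beyond the scatter) shows for (1H-imidazol-4-yl)methyl. No supporting measurement is available to explain why such different rings give matching numbers.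

The compounds shown leave open whether any aromatic ring is required here, since an aliphatic amine or a carboxylic acid on this chain carbon would test that. They also leave open how a plain phenyl ring or a longer chain to the ring would read.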